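The source may report more compounds than this note shows. Statements on the series, on what has been measured and on what is new or still open speak of the compounds shown alone.

Among the three compounds measured in an assay on isolated protein for inhibition of solute carrier family 22 member 12 (Homo sapiens), tested at 3 uM (a lower number here means less inhibition, a higher number more inhibition at the concentration tested (going by the name of the read-out)), compound 3 `N#Cc1cc(C(=O)N2CC=CC2)cc(C(F)(F)F)c1O` stands highest: compound 3 gives 83%. Nearest to it is compound 1 `N#Cc1cc(C(=O)N2CC=CC2)cc(I)c1O`, which gives 79%, a gap of a number 4 percentage points higher from compound 1 to compound 3 (within the scatter) that lies within the scatter. Furthest is compound 2 `CSc1cc(C(=O)N2CC=CC2)cc(C#N)c1O`, which gives 58%; the step is a number 25 percentage points higher from compound 2 to compound 3 (beyond the scatter), beyond the scatter. Compound 4 `N#Cc1cc(C(=O)N2CC=CC2)cc(Cl)c1O` differs from compound 3 by chloro in place of trifluoromethyl on an aromatic carbon. Among the compounds with values here, no measured step exchanges trifluoromethyl for chloro; the nearest comparison is iodo against trifluoromethyl in compound 1 and compound 3, where the step was a number 4 percentage points higher from compound 1 to compound 3 (within the scatter), within the scatter. Compound 4 is therefore expected to lie close to compound 3, at 78% with a range from 64% to 90%. The expected step is a number 5 percentage points lower from compound 3 to compound 4 (within the scatter), not beyond the scatter.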

Compound 4, a percentage reported as inhibition, at one concentration (the size of the read-out at that concentration, not a potency): 66%
Beside the measured number, compound 4's estimate is 12 percentage points above it; the range from low to high includes it.
By their numbers in this assay, from the lowest: compounds 2 and 4 (each within the scatter of the next); then compounds 1 and 3 (each within the scatter of the next).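

In this assay, within the data shown here, the position ortho to a hydroxy group proves more discriminating than the earlier compounds suggested: there is a number 17 percentage points lower from compound 3 to compound 4 (beyond the scatter) and also a number 13 percentage points lower from compound 1 to compound 4 (beyond the scatter), so chloro does not match trifluoromethyl or iodo here. With a number 8 percentage points higher from compound 2 to compound 4 (within the scatter), chloro instead falls with methylsulfanyl, and the four groups split into two levels. Nothing available explains this split. The compounds shown leave open how an amine, a methoxy group or a longer chain would read at this position. They also leave open whether the two levels would persist on a different core.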